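The source may report more compounds than this note shows. Statements on the series, on what has been measured and on what is new or still open speak of the compounds shown alone.

Working notes on the series in an assay on isolated protein for inhibition of vitamin K-dependent protein C (Homo sapiens), read by colorimetric assay, at 37 degrees C; on this read-out lower numbers stand for stronger inhibition and higher numbers for weaker inhibition.

Compound 1 `Cc1cc2ccc1[C@@H](C)COC(=O)Nc1ccc(C3CC3)c(c1)CN(C)C(=O)[C@@H]2Nc1ccc2c(N)ncc(F)c2c1` carries a cyclopropyl on the aromatic carbon in question and in this assay gives 220 nM. Compound 2 `Cc1cc2ccc1[C@@H](C)COC(=O)Nc1ccc(C3(C(=O)O)CCCC3)c(c1)CN(C)C(=O)[C@@H]2Nc1ccc2c(N)ncc(F)c2c1` carries a 1-carboxycyclopentyl at the same place and in this assay gives 340 nM. Among the measured compounds shown here, the one step measured so far, a 1.5-fold higher number from compound 1 to compound 2 (0.19 log units; within the scatter), shows that swapping a small carbocycle for a carboxylated carbocycle at this carbon leaves the inhibition constant essentially unchanged. On the two numbers shown, compound 2 sits at the higher end, but its distance from compound 1 is within the scatter, so no order between the two can be claimed.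

Compound 3 `Cc1cc2ccc1[C@@H](C)COC(=O)Nc1ccc(C3(C(=O)O)CCOCC3)c(c1)CN(C)C(=O)[C@@H]2Nc1ccc2c(N)ncc(F)c2c1` is the next member: 4-carboxyoxan-4-yl in place of 1-carboxycyclopentyl on an aromatic carbon. The carboxyl substituent is kept; the carbocycle becomes a six-membered ring with one hetero atom. For the measured compounds named here, only the step from compound 1 to compound 2 bears on this change, and it was within the scatter, so for compound 3 no step beyond the scatter is expected in this assay, a 1.0-fold higher number from compound 2 to compound 3 (0.01 log units; within the scatter). The estimate for compound 3 is therefore 350 nM, with a range from 170 nM to 720 nM.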

Compound 3, inhibition constant: 1600 nM
For compound 3 the middle estimate is 4.6-fold (0.66 log units) below the measured one; measured number outside the range, above it.
By their numbers in this assay, from the lowest: compounds 1 and 2 (each within the scatter of the next); then compound 3.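

With the carboxyl kept, replacing the five-membered ring of carbon only with a six-membered ring with one hetero atom gives a 4.7-fold higher number from compound 2 to compound 3 (0.67 log units; beyond the scatter) in this assay and so moves the read-out beyond the scatter, which the earlier step from a cyclopropyl to a 1-carboxycyclopentyl did not do. The aromatic carbon therefore does not accept every carboxylated ring equally, and the ring carrying the carboxyl counts here, not the carboxyl alone; against the cyclopropyl of compound 1 the same holds, with a 7.3-fold higher number from compound 1 to compound 3 (0.86 log units; beyond the scatter) in the same assay. Nothing on hand gives a reason for this step.

As far as these compounds go, what remains open is whether the step follows the larger ring or the ring oxygen, since the two change together between compound 2 and compound 3. A 1-carboxycyclohexyl at this carbon would separate those two changes, while an oxan-4-yl without the carboxylic acid would show whether the ring oxygen has the same effect without the carboxyl on the ring.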